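From a 2-methylbenzyl amide to its 3,5-difluorobenzyl counterpart

The source may hold more compounds than are shown below. What is called first, only, known or untested is meant among the compounds shown, and "the series" means these compounds.

Three compounds sharing one core were measured in a functional assay on Jurkat cells (Homo sapiens); on this read-out higher numbers stand for weaker inhibition and lower numbers for stronger inhibition. Compound 1 `C[C@H](NC(=O)C(=O)NCC1(c2ccccc2)CC1)C(=O)N[C@@H](CC(=O)O)C(=O)COc1c(F)c(F)cc(F)c1F` gives 27 nM, compound 2 `Cc1ccccc1CNC(=O)C(=O)N[C@@H](C)C(=O)N[C@@H](CC(=O)O)C(=O)COc1c(F)c(F)cc(F)c1F` gives 52 nM, and compound 3 `C[C@H](NC(=O)C(=O)NCc1cc(Cl)cc(Cl)c1)C(=O)N[C@@H](CC(=O)O)C(=O)COc1c(F)c(F)cc(F)c1F` gives 23 nM. Of the three numbers, compound 2's is the largest, but the step of a 1.9-fold higher number from compound 1 to compound 2 (0.28 log units; within the scatter) stays within the scatter, so compound 1 and compound 2 cannot be told apart on this assay, whereas the step of a 2.3-fold lower number from compound 2 to compound 3 (0.35 log units; beyond the scatter) lies beyond it. The step of a 1.2-fold lower number from compound 1 to compound 3 (0.07 log units; within the scatter) is likewise within the scatter.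

Compound 4 `C[C@H](NC(=O)C(=O)NCc1cc(F)cc(F)c1)C(=O)N[C@@H](CC(=O)O)C(=O)COc1c(F)c(F)cc(F)c1F` has not yet been measured in this assay. Relative to compound 2 it carries 3,5-difluorophenyl in place of 2-methylphenyl on a saturated chain carbon bound to an amide-type nitrogen. For the measured compounds named here, the step that bears on this most directly is the one from compound 2 to compound 3, where a 3,5-dichlorophenyl also entered in place of the 2-methylphenyl and the number fell by a 2.3-fold lower number from compound 2 to compound 3 (0.35 log units; beyond the scatter). Since compound 4 carries the same substitution pattern with fluorine instead of chlorine, a step in the same direction, of roughly that size or a little smaller, is expected: a 1.7-fold lower number from compound 2 to compound 4 (0.24 log units; within the scatter). On that basis compound 4 is estimated at 30 nM in this assay, with a range from 12 nM to 75 nM.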

Compound 4, half-maximal inhibitory concentration: 16 nM
Estimate against measurement, compound 4: 1.9-fold (0.27 log units) above; low and high end bracket the measured number.
By their numbers in this assay, from the lowest: compounds 4, 3, 1 and 2 (each within the scatter of the next, the first and the last beyond it).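

In this assay, replacing the 2-methylphenyl on a saturated chain carbon bound to an amide-type nitrogen with 3,5-difluorophenyl gives a step beyond the scatter (a 3.3-fold lower number from compound 2 to compound 4 (0.51 log units; beyond the scatter)), so two 3,5-dihalophenyl groups, not only the 3,5-dichlorophenyl, now separate from the 2-methylphenyl. The identity of the halogen is not resolved at this place, since exchanging 3,5-dichlorophenyl for 3,5-difluorophenyl stays within the scatter (a 1.4-fold lower number from compound 3 to compound 4 (0.16 log units; within the scatter)), and the 1-phenylcyclopropyl group cannot be told apart from the 3,5-difluorophenyl either (a 1.7-fold lower number from compound 1 to compound 4 (0.23 log units; within the scatter)). Nothing shown gives a reason for these differences.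

The compounds shown leave open whether the two halogens are needed at all, as a plain phenyl or a 3,5-dimethylphenyl group at this place would test, and whether the 2-methylphenyl number comes from the methyl group itself or from where it sits on the ring. They also leave open whether a larger 3,5-dibromophenyl group or a 3,5-dimethoxyphenyl group would stay within the scatter of compound 4.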